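From 1H-indol-3-yl to 4-chlorophenyl in compound 3

A few compounds are considered here, and "the series" means these few. Any claim that something is new, unique, unknown or untested is made for them only; others in the source may bear on it.

Values measured in a functional assay on DU-145 cells (Homo sapiens) for inhibition, read by trypan blue exclusion, with a stated time of 96 h (a lower number here means a stronger inhibitor of growth, a higher number a weaker inhibitor of growth), are:
- compound 1 `O=C(/C(=C\c1ccc(Cl)cc1)Sc1ccc(Cl)cc1)c1ccc(Cl)cc1` gives 1000 nM
- compound 2 `COc1ccccc1/C=C(/SCc1ccc(F)cc1)C(=O)c1ccc(Cl)cc1` gives 10000 nM
- compound 3 `O=C(/C(=C\c1c[nH]c2ccccc12)SCc1ccc(F)cc1)c1ccc(Cl)cc1` gives 1000 nM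

Compound 3 stands level with compound 1, together the lowest of the three numbers. Compound 4 `O=C(/C(=C\c1ccc(Cl)cc1)SCc1ccc(F)cc1)c1ccc(Cl)cc1` carries 4-chlorophenyl in place of 1H-indol-3-yl on a double-bonded chain carbon bound to a double-bonded chain carbon. Among the measured compounds shown here, the one measured step at this place (a 10-fold lower number from compound 2 to compound 3 (1.00 log units; beyond the scatter)) came with 1H-indol-3-yl replacing 2-methoxyphenyl, so losing 1H-indol-3-yl could reverse part of it. Against that, compound 1 also has 4-chlorophenyl there and gives 1000 nM despite differing elsewhere. A small move to a higher number is therefore expected (a 2.0-fold higher number from compound 3 to compound 4 (0.30 log units; within the scatter)). Compound 4 is expected at 2000 nM (estimated range 500 nM to 10000 nM).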

Compound 4, concentration for 50% growth inhibition: 10000 nM
Compound 4: middle estimate off by 5.0-fold (0.70 log units), on the low side, within the range that was stated.
By their numbers in this assay, from the lowest: compounds 1 and 3 (each within the scatter of the next); then compounds 2 and 4 (each within the scatter of the next).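

In this assay, the change to 4-chlorophenyl gave a 10-fold higher number from compound 3 to compound 4 (1.00 log units; beyond the scatter) and so lost what 1H-indol-3-yl had gained, while 4-chlorophenyl in place of 2-methoxyphenyl gave no change at the digits printed from compound 2 to compound 4 (within the scatter). With 4-fluorobenzyl on the sulfur, 1H-indol-3-yl alone therefore stands apart among the three groups at this place. The match between compound 1 and compound 3 did not extend to compound 4, as 4-fluorobenzyl in place of 4-chlorophenyl on a sulfur gave a 10-fold higher number from compound 1 to compound 4 (1.00 log units; beyond the scatter).

Nothing available accounts for these differences. From the compounds shown here alone, how a pyridine ring or an aminophenyl group would fare at this place remains open.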